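Swapping Halogens on the Sulfonyl Aryl Ring

The source may hold more compounds than are shown below. What is called first, only, known or untested is meant among the compounds shown, and "the series" means these compounds.

Compound 1 `CC1CCN(C2CCN(S(=O)(=O)c3ccc(F)cc3F)CC2)CC1` stands second highest of three measured compounds in a functional assay on DLD-1 cells (Homo sapiens) for antiproliferative activity, read by CellTiter-Glo, with a stated time of 72 h (a higher number here means a weaker inhibitor, a lower number a stronger inhibitor), where compound 1 gives 102 nM. Compound 2 `CC1CCN(C2CCN(S(=O)(=O)c3ccc(C(C)C)cc3)CC2)CC1` gives 685 nM, and compound 3 `CC1CCN(C2CCN(S(=O)(=O)c3ccc(-c4ccccc4F)cc3)CC2)CC1` gives 5 nM. Among the measured compounds shown here, the one measured step, a 140-fold lower number from compound 2 to compound 3 (2.14 log units; beyond the scatter), shows that the group on the sulfonyl sulfur can shift this number a great deal. Compound 4 `CC1CCN(C2CCN(S(=O)(=O)c3cccc(Cl)c3)CC2)CC1` differs from compound 1 by 3-chlorophenyl in place of 2,4-difluorophenyl on a sulfonyl sulfur. For the measured compounds named here, no measured step exchanges one halogen-bearing phenyl ring for another, so the step from compound 2 to compound 3 is only a loose guide; since both rings are phenyl rings carrying halogens, a small step within the scatter is expected: a 1.5-fold higher number from compound 1 to compound 4 (0.17 log units; within the scatter). Compound 4 is therefore estimated at 150 nM, with a range from 40 nM to 600 nM.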

Compound 4, half-maximal inhibitory concentration: > 5000 nM
Compound 4: only a limit was reported (the forecaster's own chance of this, stated with the estimate: 2%); middle value at least 33-fold (1.52 log units) from the limit.
By their numbers in this assay, from the lowest: compound 3; then compound 1; then compound 2. At a limit, above all of these: compound 4.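

On the sulfonyl sulfur, even an exchange of one halogen-bearing phenyl ring for another can matter greatly: 3-chlorophenyl in place of 2,4-difluorophenyl gives an at least 49-fold higher number from compound 1 to compound 4 (1.69 log units; beyond the scatter). The earlier step changed a ring substituent of a different kind, whereas here both rings are halogen-bearing phenyl rings. For compound 4 in this assay, the reported result is a limit, not a number: the limit of > 5000 nM in this assay, at which 1 of the 4 values shown sits.

The two rings differ both in their halogen and in where it sits, and the compounds shown do not separate these two changes. A 3-fluorophenyl or 2,4-dichlorophenyl ring on the sulfonyl sulfur would bear directly on that question.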